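Swapping chloro for nitro on the sulfonyl phenyl ring

The source may hold more compounds than are shown below. What is called first, only, known or untested is meant among the compounds shown, and "the series" means these compounds.

Measured compounds:
- compound 1, `CCCCC(CC)C(=O)Nc1ccc2ccn(Cc3ccc(C(=O)NS(=O)(=O)c4ccc(Cl)cc4)cc3OC)c2c1`: 7.8
- compound 2, `COc1cc(C(=O)NS(=O)(=O)c2ccc3ccccc3c2)ccc1Cn1ccc2ccc(NC(=O)CC3CCCC3)cc21`: 8.3
- compound 3, `COc1cc(C(=O)NS(=O)(=O)c2ccccc2Cl)ccc1Cn1ccc2ccc(NC(=O)CC3CCCC3)cc21`: 9.8

In a functional assay (trachea) for antagonist activity, with Cavia porcellus as the target (a higher number here means a more potent compound, by a factor of ten per unit of this negative logarithm, a lower number a less potent compound), compound 1 gives the lowest of the three numbers: compound 2 sits higher, and compound 3 sits higher still. The one single-point step among these three, a number 1.50 log units higher from compound 2 to compound 3 (beyond the scatter), concerns the aryl group on the sulfonyl sulfur and shows that this region can move the read-out a great deal.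

Compound 4, `CCCCC(CC)C(=O)Nc1ccc2ccn(Cc3ccc(C(=O)NS(=O)(=O)c4ccc([N+](=O)[O-])cc4)cc3OC)c2c1`, differs from compound 1 by nitro in place of chloro on an aromatic carbon. Going by the values given here, this is also a change on the aryl group attached to the sulfonyl sulfur, so the step from compound 2 to compound 3 indicates that the region matters, but no measured pair shows what nitro does in place of chloro. With nothing directly comparable, the expectation is a step of no size beyond the scatter, no change at the digits printed from compound 1 to compound 4 (within the scatter), though the range is kept wide because the region is sensitive. Compound 4 is therefore estimated at 7.8, between 7.1 and 8.5.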

Compound 4, negative logarithm of the antagonist equilibrium constant: 7.7
Beside the measured number, compound 4's estimate is 0.10 log units above it, within the range that was stated.
By their numbers in this assay, from the lowest: compounds 4 and 1 (each within the scatter of the next); then compound 2; then compound 3.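

In this assay nitro in place of chloro on the aromatic carbon of the sulfonyl phenyl ring gives a number 0.10 log units lower from compound 1 to compound 4 (within the scatter) and so leaves the two groups indistinguishable at this position, even though nitro brings more heavy atoms and two hydrogen-bond acceptors. The aryl group on the sulfonyl sulfur can still matter, as a number 1.50 log units higher from compound 2 to compound 3 (beyond the scatter) shows, but that larger step came from a different exchange, and the sensitivity of this region does not extend to every change made on it. No measurement available here accounts for the close agreement between chloro and nitro.

Going by these compounds, whether an amine or a carboxylic acid on the same carbon would also match chloro remains open. So does whether nitro and chloro would stay this close on the side chain carried by compounds 2 and 3.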